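Changing the aryl group on the amide nitrogen of a pyridine N-oxide series

The compounds below may be only part of what the source reports. "The series", "measured", "known", "first", "only" and "open" are said of these compounds alone.

Compound 3 `Cc1cc(F)ccc1NC(=O)CN1CCC(c2cccc[n+]2[O-])CC1` is one of three compounds with numbers in a functional assay on HEK293 cells for agonist activity at D(4) dopamine receptor (Homo sapiens), read by FLIPR; on this read-out lower numbers stand for an effect already at smaller amounts and higher numbers for an effect only at larger amounts of compound. In this assay compound 3 gives 60 nM, the second highest of the three numbers. Compound 1 `O=C(CN1CCC(c2cccc[n+]2[O-])CC1)Nc1cccc(Cl)c1` gives 62 nM, which sits within the scatter of compound 3, so the two cannot be told apart. Compound 2 `Cc1cccc(NC(=O)CN2CCC(c3ccccc3C#N)CC2)c1`, which carries a different group on the shared core, gives 8 nM, a lower number that stands beyond the scatter from compound 3.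

Compound 4 `Cc1cccc(C)c1NC(=O)CN1CCC(c2cccc[n+]2[O-])CC1` is not yet measured. It differs from compound 3 in one place: 2,6-dimethylphenyl in place of 4-fluoro-2-methylphenyl on an amide-type nitrogen.

For the measured compounds named here, only one measured step changes the group on the same amide-type nitrogen: a 1.0-fold lower number from compound 1 to compound 3 (0.01 log units; within the scatter). That swap of one aryl group for another left the number where it was. Going by the values given here, no measured pair shows the exact change to 2,6-dimethylphenyl, so the expectation rests on that single step alone. The number for compound 4 in this assay is therefore expected to stay close to that of compound 3, with an expected step of no change at the digits printed from compound 3 to compound 4 (within the scatter). Compound 4 is estimated at 60 nM, within a range from 25 nM to 150 nM.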

Compound 4, half-maximal effective concentration: 346 nM
For compound 4 the middle estimate is 5.8-fold (0.76 log units) below the measured one; measured number outside the range, above it.
By their numbers in this assay, from the lowest: compound 2; then compounds 3 and 1 (each within the scatter of the next); then compound 4.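

The position on the amide-type nitrogen is not indifferent to its aryl group: in this assay, 2,6-dimethylphenyl gives a 5.8-fold higher number from compound 3 to compound 4 (0.76 log units; beyond the scatter) and a 5.6-fold higher number from compound 1 to compound 4 (0.75 log units; beyond the scatter), so this group stands apart from both earlier aryl groups, which could not be told apart from each other. The first of these steps keeps the count of heavy atoms, the single aromatic ring and the zero hydrogen-bond donors and acceptors, and exchanges only a fluorine for a carbon, so these counts alone do not track the number. Nothing measured here bears on why the number rises.

Open, from the compounds shown here alone, is how a plain phenyl, or a 2-methylphenyl without the fluorine, would read at this position. Also open, going by these compounds, is whether 2,6-dimethylphenyl gives a similar step on the core of compound 2, which carries a nitrile.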